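Chain-terminal group swap in a piperidine ester series

This account rests on a few compounds, and the source may have more. Where it says the series, first, only, none or still open, it means among the compounds named here.

Of the compounds shown here, two carry a number so far. Compound 1 `COc1ccc(OCCCCCN2CCCC(COC(=O)c3ccccc3N3C(=O)CC(C)C3=O)C2)cc1OC` gives 8320 nM in an in vitro functional assay on HEK ts201 cells for antagonist activity at Neuronal acetylcholine receptor; alpha4/beta2 (Homo sapiens), read by fluorescence and calcium flux; on this read-out higher numbers stand for weaker inhibition and lower numbers for stronger inhibition. Compound 2 `O=C(OCC1CCCN(CCCc2ccccc2)C1)c1ccccc1-c1cccc2ccccc12` gives 11700 nM in this assay; this value and that of compound 1 lie within the scatter of each other, so no order between the two can be read. Among the measured compounds shown here, compound 1 holds the lower of the two numbers, with compound 2 its only neighbour.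

Compound 3 `CC1CC(=O)N(c2ccccc2C(=O)OCC2CCCN(CCCCCCc3ccccc3)C2)C1=O` has not been measured. It departs from compound 1 by benzyl in place of 3,4-dimethoxyphenoxy on a saturated chain carbon, five bonds along the chain from an amine nitrogen in a ring. For the measured compounds named here, no measured pair with the same change exists, so its effect is unknown. Both measured compounds sit in the same weak region, which gives no ground to expect a move beyond the scatter. For compound 3 the expected step of a 1.2-fold higher number from compound 1 to compound 3 (0.08 log units; within the scatter) is therefore one that stays within the scatter. The estimate for compound 3 in this assay is 10000 nM, with a range from 3000 nM to 35000 nM.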

Compound 3, half-maximal inhibitory concentration: 29500 nM
Compound 3: the middle estimate sits 3.0-fold (0.47 log units) below what was measured; low and high end bracket the measured number.
By their numbers in this assay, from the lowest: compounds 1 and 2 (each within the scatter of the next); then compound 3.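

In this assay, among the compounds shown here, benzyl in place of 3,4-dimethoxyphenoxy on a saturated chain carbon, five bonds along the chain from an amine nitrogen in a ring, gives a 3.5-fold higher number from compound 1 to compound 3 (0.55 log units; beyond the scatter), the first change at a single place that can be read. The position is therefore not indifferent to its terminal group, and in this one pair the change goes towards weaker inhibition. The swap alters several things at once, from 11 heavy atoms to 7 and from 3 hydrogen-bond acceptors to 0, and no measurement at hand separates these differences or ties the step to any one of them.

Open, going by these compounds, is which part of the 3,4-dimethoxyphenoxy group matters: an unsubstituted phenoxy or a single methoxy on the ring would divide the ether oxygen from the methoxy groups. Also open, on these data alone, is how a terminal amide or carboxylic acid would read at this position.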